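Smaller aryl group in place of naphthalen-2-yl

A few compounds are considered here, and "the series" means these few. Any claim that something is new, unique, unknown or untested is made for them only; others in the source may bear on it.

Three compounds carry numbers in an assay on isolated protein (Bos taurus) for inhibition of geranylgeranyl transferase type-1 subunit beta (Homo sapiens); on this read-out lower numbers stand for stronger inhibition and higher numbers for weaker inhibition. Compound 1 `Cn1cncc1C(OCc1ccc(C#N)cc1)c1ccc(C#N)c(-c2cccc3cccnc23)c1` gives 103 nM, compound 3 `Cn1cncc1C(OCc1ccc(C#N)cc1-c1cccc(OC(F)(F)F)c1)c1ccc(C#N)nc1` gives 990 nM, and compound 2 `Cn1cncc1C(OCc1ccc(C#N)nc1-c1ccc2ccccc2c1)c1ccc(C#N)cc1` gives 5500 nM, the highest of the three; its nearest neighbour, compound 3, lies beyond the scatter from it, and compound 1 further still. No two of these three differ in a single place, so no step can be read among them. Compound 4 `Cn1cncc1C(OCc1ccc(C#N)nc1-c1cccc(Cl)c1)c1ccc(C#N)cc1` differs from compound 2 in one place: 3-chlorophenyl in place of naphthalen-2-yl on an aromatic carbon. With no measured step of this kind in the set, the direction is uncertain; a modest move toward a lower number is expected, a 2.8-fold lower number from compound 2 to compound 4 (0.44 log units; beyond the scatter), though a result within the scatter would not surprise. Compound 4 is therefore estimated at 2000 nM, within 500 nM to 8000 nM.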

Compound 4, half-maximal inhibitory concentration: 1700 nM
Beside the measured number, compound 4's estimate is 1.2-fold (0.07 log units) above it; the range from low to high includes it.
By their numbers in this assay, from the lowest: compound 1; then compounds 3 and 4 (each within the scatter of the next); then compound 2.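

Among these compounds, this is the first step read at this position: at the aromatic carbon next to the ring nitrogen, 3-chlorophenyl in place of naphthalen-2-yl gives a 3.2-fold lower number from compound 2 to compound 4 (0.51 log units; beyond the scatter) in this assay. The second ring of naphthalen-2-yl is therefore not needed here for inhibition, and the one-ring group reads better, though the step is modest. No measurement bearing on the reason for this step is available.

As far as these compounds go, whether the chlorine contributes to the step remains open, since a plain phenyl group would be needed to separate it from the loss of the second ring. Also open, from the compounds shown here alone, is how this carbon responds to a non-aryl group, such as an amine like morpholine.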